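A few compounds are considered here, and "the series" means these few. Any claim that something is new, unique, unknown or untested is made for them only; others in the source may bear on it.

The compounds measured so far, with their results in a functional assay on ECa-109 cells (Homo sapiens) for cytotoxicity, read by MTT assay, with a stated time of 48 h; a higher number here means a weaker inhibitor, a lower number a stronger inhibitor:

Compound 1, `O=C1C(O)=C(C(c2ccc([N+](=O)[O-])cc2)c2c[nH]c3ccccc23)C(=O)c2ccccc21`, gives 60900 nM.
Compound 2, `COc1ccc(C(C2=C(O)C(=O)c3ccccc3C2=O)c2c[nH]c3ccccc23)cc1Br`, gives 11800 nM.
Compound 3, `O=C1C(O)=C(C(c2cccc([N+](=O)[O-])c2)c2c(-c3ccccc3)[nH]c3ccccc23)C(=O)c2ccccc21`, gives 5830 nM.

Compound 2 stands second highest of these three numbers: compound 3 shows a lower number and compound 1 a higher one, and both gaps lie beyond the usual scatter. Compound 4, `O=C1C(O)=C(C(c2ccc(Cl)cc2)c2c[nH]c3ccccc23)C(=O)c2ccccc21`, differs from compound 2 in one place: 4-chlorophenyl in place of 3-bromo-4-methoxyphenyl on a saturated chain carbon bound to an aromatic carbon and a double-bonded ring carbon. For the measured compounds named here, only one measured step alters the group at the same place: a 5.2-fold lower number from compound 1 to compound 2 (0.71 log units; beyond the scatter). That step exchanged one aryl group for another and shifted the number by a modest amount, but neither of those aryl groups is 4-chlorophenyl, so the direction of the present change cannot be read from it directly. The step is therefore expected to be small, most likely toward a somewhat higher number, estimated as a 1.7-fold higher number from compound 2 to compound 4 (0.23 log units; within the scatter). Compound 4 is expected to give about 20000 nM in this assay, within a range from 6000 nM to 60000 nM.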

Compound 4, half-maximal inhibitory concentration: 45800 nM
Beside the measured number, compound 4's estimate is 2.3-fold (0.36 log units) below it; the range from low to high includes it.
By their numbers in this assay, from the lowest: compound 3; then compound 2; then compounds 4 and 1 (each within the scatter of the next).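

In this assay, the change of aryl group on the saturated chain carbon gives a 3.9-fold higher number from compound 2 to compound 4 (0.59 log units; beyond the scatter), so the lower number seen with 3-bromo-4-methoxyphenyl does not carry over to 4-chlorophenyl. Chloro in place of nitro on an aromatic carbon gives a 1.3-fold lower number from compound 1 to compound 4 (0.12 log units; within the scatter), which lies within the scatter, so these two groups cannot be told apart here and compound 2 alone stands clear of both. Nothing available explains why the 3-bromo-4-methoxyphenyl group differs from the other two.

The compounds shown leave open whether the bromo group, the methoxy group or the two together set compound 2 apart, which a phenyl ring carrying only one of them could help to separate. Also open, from the compounds shown here alone, is how an amine or a carboxylic acid on that ring would read in this assay.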